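Adding an acetyl to the amine of compound 2

The source may report more compounds than this note shows. Statements on the series, on what has been measured and on what is new or still open speak of the compounds shown alone.

compound 1 `CCCCc1ccc(-c2ccc(-c3cc(C(=O)O)c4cc(Br)ccc4n3)o2)cc1`: 2130 nM
compound 2 `CCCCc1ccc(-c2ccc(-c3cc(C(=O)O)c4cc(N)ccc4n3)o2)cc1`: "not active" (no number reported)

In a functional assay on BJAB cells (Homo sapiens) for cytotoxicity, read by luminescence and CellTiter-Glo, with a stated time of 72 h (on this read-out higher numbers stand for an effect only at larger amounts of compound and lower numbers for an effect already at smaller amounts), compound 1 gives 2130 nM, while compound 2 is reported as "not active" (no number reported). Compound 2 therefore has no single number and cannot be given an exact place on the scale. Compound 3 `CCCCc1ccc(-c2ccc(-c3cc(C(=O)O)c4cc(NC(C)=O)ccc4n3)o2)cc1` keeps the shared core and differs from compound 2 in one place: acetyl in place of hydrogen on a nitrogen on an aromatic ring. Put simply, amino becomes acetamido.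

Among the compounds with values here, no measured pair shows what this change does, so the size of the step cannot be stated. The expected direction is towards a measurable effect, though compound 3 may also fail to give a number. Within the data shown here, the only support is that compound 1 gives 2130 nM on the same core. For compound 3 the estimated value is 6000 nM, with an expected range of 1500 nM to 25000 nM.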

Compound 3, half-maximal effective concentration: "not active" (no number reported)
Nothing numeric was reported for compound 3, and the estimate cannot be compared.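

In this assay compound 2 gives "not active" (no number reported) and compound 3 gives "not active" (no number reported) as well, so no step can be read between them. No measurement shown offers an explanation for this result. The compounds shown leave open how far amino and acetamido on the shared core each lie from a measurable effect.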